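This account rests on a few compounds, and the source may have more. Where it says the series, first, only, none or still open, it means among the compounds named here.

Measured so far in a functional assay on the whole organism (strain Wistar) for inhibition, with Rattus norvegicus as the target, read by paw edema, with a stated time of 4 h, at a dose of 10 mg/kg by the intraperitoneal route; on this read-out lower numbers stand for less inhibition and higher numbers for more inhibition at the one dose given (going by the name of the read-out):
compound 1 `O=C(N/N=C/c1cccc(F)c1)c1cccnc1Nc1cccc(C(F)(F)F)c1`: 29.8%
compound 2 `O=C(N/N=C/c1ccc(O)c(O)c1)c1cccnc1Nc1cccc(C(F)(F)F)c1`: 21.1%

Within the data shown here, compound 2 shows the lower of the two numbers, but the only measured step, a number 8.7 percentage points lower from compound 1 to compound 2 (within the scatter), lies within the scatter, so the two compounds are not separated. Compound 3 `COc1ccc(/C=N/NC(=O)c2cccnc2Nc2cccc(C(F)(F)F)c2)cc1OC` differs from compound 2 by 3,4-dimethoxyphenyl in place of 3,4-dihydroxyphenyl on a carbon with a double bond to nitrogen. Among the measured compounds shown here, no measured step exchanges these two groups; the one step available concerns a different pair of groups and stayed within the scatter, so nothing beyond the scatter is expected in this assay. Compound 3 is estimated at 25%, range 12% to 38%. The expected step is a number 3.9 percentage points higher from compound 2 to compound 3 (within the scatter).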

Compound 3, a percentage reported as inhibition, in the whole organism at one dose (the size of the read-out at that dose, not a potency): 52.9%
The estimate for compound 3 lay 27.9 percentage points below the measured number, outside the stated range (above it).
By their numbers in this assay, from the lowest: compounds 2 and 1 (each within the scatter of the next); then compound 3.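

In this assay, the group on a carbon with a double bond to nitrogen can move the read-out: the step is a number 31.8 percentage points higher from compound 2 to compound 3 (beyond the scatter) with 3,4-dimethoxyphenyl in place of 3,4-dihydroxyphenyl. The same group also separates from 3-fluorophenyl, with a number 23.1 percentage points higher from compound 1 to compound 3 (beyond the scatter) as the step, so compound 3 stands highest of the three.

On these data alone, whether ethoxy groups, a single methoxy group or a dimethylamino group would hold this level remains open. The reason for the gap also remains open, as no measurement here bears on it.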